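Ortho substituent series on a shared oxadiazole-thiazole core: cytotoxicity

The compounds below may be only part of what the source reports. "The series", "measured", "known", "first", "only" and "open" are said of these compounds alone.

Measured compounds:
- compound 1 `COc1ccccc1-c1nnc(-c2sc(-c3cccnc3)nc2C)o1` — in an ADME assay on HeLa cells (Homo sapiens) for cytotoxicity, read by MTT assay (a higher number here means that more compound is tolerated, a lower number that less compound is tolerated), compound 1 gives > 100 ug/mL, which is a limit of the assay, not a number.
- compound 2 `Cc1nc(-c2cccnc2)sc1-c1nnc(-c2ccccc2)o1` — in this assay compound 2 gives > 100 ug/mL, again a limit.
- compound 3 `Cc1ccccc1-c1nnc(-c2sc(-c3cccnc3)nc2C)o1` — in this assay compound 3 gives > 100 ug/mL, likewise a limit.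

Compound 3 therefore stands at the limit, as do both other measured compounds; no ranking among the three is possible. The steps from compound 1 to compound 2 a step that the two limits leave unreadable from compound 1 to compound 2, from compound 1 to compound 3 a step that the two limits leave unreadable from compound 1 to compound 3 and from compound 2 to compound 3 a step that the two limits leave unreadable from compound 2 to compound 3 are all unreadable, because of the limit of > 100 ug/mL in this assay, at which 3 of the 3 values shown sit.

Compound 4 `Cc1nc(-c2cccnc2)sc1-c1nnc(-c2ccccc2[N+](=O)[O-])o1` differs from compound 3 by nitro in place of methyl on an aromatic carbon. Within the data shown here, of the measured steps, the one from compound 2 to compound 3 and the one from compound 1 to compound 3 touch the same carbon, but neither gives a readable size, so nothing in the data sets a direction for the new step. The step from compound 3 to compound 4 is therefore expected to be a number no higher from compound 3 to compound 4 (the limit leaves the size open), that is, none beyond the scatter. In this assay compound 4 is expected to give about 100 ug/mL, between 50 ug/mL and 200 ug/mL, most likely reported again as a limit.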

Compound 4, half-maximal cytotoxic concentration: > 100 ug/mL
Compound 4 gave a limit, no number; the forecaster's own chance of this, stated with the estimate: 80%; the middle value sits exactly at the limit.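

In this assay compound 4 gives > 100 ug/mL, a limit of the assay and not a number. The steps to compound 4 from compound 1, compound 2 and compound 3 cannot be read, because all four compounds share one limit: the limit of > 100 ug/mL in this assay, at which 4 of the 4 values shown sit.

The compounds shown leave open whether hydrogen, methoxy, methyl or nitro on this aromatic carbon makes any difference to the tolerated concentration.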